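A Chloro Added to Compound 3: Expected Potency

The source may hold more compounds than are shown below. What is called first, only, known or untested is meant among the compounds shown, and "the series" means these compounds.

Of the compounds shown here, three built on one shared core have been tested in an assay on isolated protein for inhibition of tyrosine-protein kinase receptor UFO (Homo sapiens), read by FRET and Z'-LYTE, with a stated time of 1.5 h; a higher number here means a weaker inhibitor, a lower number a stronger inhibitor. Compound 1 `CCc1ccc2c(c1)c(=O)c(C(=O)Nc1ccc(Oc3cccc4occ(-c5ccccc5)c34)c(F)c1)c(C)n2C` gives 192 nM in this assay. Compound 2 `CCc1ccc2c(c1)c(=O)c(C(=O)Nc1ccc(Oc3ccnc(Cl)c3)c(F)c1)c(C)n2C` reaches only the limit of this assay, reported as > 10000 nM, so no number is known for it. Compound 3 `CCc1ccc2c(c1)c(=O)c(C(=O)Nc1ccc(Oc3ccnc(N)c3)c(F)c1)c(C)n2C` gives 888 nM in this assay, which is the higher of the two numbers actually reported; compound 1 sits a clear step below it, beyond the usual scatter.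

Among the compounds with values here, only one measured step touches the same ring: an at least 11-fold lower number from compound 2 to compound 3 (1.05 log units; beyond the scatter). Its true size is blurred because compound 2 rests at the limit of > 10000 nM in this assay, at which 1 of the 3 values shown sits. It does show that what sits on this ring can move the number a great deal.

Compound 4 `CCc1ccc2c(c1)c(=O)c(C(=O)Nc1ccc(Oc3ccnc(N)c3Cl)c(F)c1)c(C)n2C` differs from compound 3 by chloro in place of hydrogen on an aromatic carbon. Within the data shown here, no measured pair shows a chloro entering in place of hydrogen, so the size of this step has to be guessed from the amino-bearing parent alone. In this assay compound 4 is expected to give about 700 nM, with a likely range from 200 nM to 3000 nM. The step from compound 3 is therefore estimated as a 1.3-fold lower number from compound 3 to compound 4 (0.10 log units; within the scatter), not clearly beyond the scatter in either direction.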

Compound 4, half-maximal inhibitory concentration: 72 nM
Compound 4: the middle estimate sits 9.7-fold (0.99 log units) above what was measured; measured number outside the range, below it.
By their numbers in this assay, from the lowest: compound 4; then compound 1; then compound 3. At a limit, above all of these: compound 2.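

Placing a chloro on the aromatic carbon ortho to the amino group, two atoms from the ring nitrogen, gives in this assay a 12-fold lower number from compound 3 to compound 4 (1.09 log units; beyond the scatter), so a ring position that carries only hydrogen in compound 3 can by itself move the number well beyond the scatter. The earlier step on this ring showed a change at a different carbon, and the new chloro acts in the same direction, so that with the amino group and the chloro both in place the full change reads an at least 130-fold lower number from compound 2 to compound 4 (2.14 log units; beyond the scatter). Compound 2 rests at a limit of the assay and not at a number, so the true size of that wider step cannot be read: the limit of > 10000 nM in this assay, at which 1 of the 4 values shown sits.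

Chloro is the only group shown at this position, so it stays open whether fluoro, bromo, methyl or a nitrile there would give a similar number in this assay. On these data alone, it also stays open whether the chloro would have the same effect with a methylamino group or a hydroxyl in place of the amino group.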